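Sulfamoylphenyl in place of bromophenyl on the aromatic nitrogen

The compounds below may be only part of what the source reports. "The series", "measured", "known", "first", "only" and "open" are said of these compounds alone.

In a functional assay on HepG2 cells (Homo sapiens) for antiproliferative activity, read by MTT assay, with a stated time of 48 h (a higher number here means a weaker inhibitor, a lower number a stronger inhibitor), compound 1 `N#CC1=C(N)Oc2c(c3nc4ccccc4nc3c3ccccc23)C12C(=O)N(Cc1cnnn1-c1ccccc1Br)c1ccccc12` gives > 50000 nM, a limit of the assay rather than a number. Compound 2 `N#CC1=C(N)Oc2c(c3nc4ccccc4nc3c3ccccc23)C12C(=O)N(Cc1cnnn1-c1cccc(Br)c1)c1ccccc12` gives > 50000 nM, again a limit. The step that the two limits leave unreadable from compound 1 to compound 2 is unreadable, as both values sit at the limit of > 50000 nM in this assay, at which 2 of the 2 values shown sit. Compound 3 `N#CC1=C(N)Oc2c(c3nc4ccccc4nc3c3ccccc23)C12C(=O)N(Cc1cnnn1-c1ccc(S(N)(=O)=O)cc1)c1ccccc12` differs from compound 2 by 4-sulfamoylphenyl in place of 3-bromophenyl on an aromatic nitrogen. Going by the values given here, no measured step gives a readable size for this change in this assay. Compound 3 is expected to stay at the limit, with an estimated step that the limit leaves unreadable from compound 2 to compound 3. For compound 3 the estimate is 80000 nM, within 30000 nM to 300000 nM.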

Compound 3, half-maximal inhibitory concentration: 42200 nM
Estimate against measurement, compound 3: 1.9-fold (0.28 log units) above, within the range that was stated.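

In this assay, going by these compounds alone, compound 3, with 4-sulfamoylphenyl on the aromatic nitrogen, gives 42200 nM, the only number at this position rather than a limit. The change reads as an at least 1.1-fold lower number from compound 2 to compound 3 (0.07 log units; that floor lies within the scatter) and as an at least 1.1-fold lower number from compound 1 to compound 3 (0.07 log units; that floor lies within the scatter), so a readable value appears here but no difference beyond the scatter is established. Compound 1 and compound 2 remain limits of the assay: the limit of > 50000 nM in this assay, at which 2 of the 3 values shown sit.

Open, on these data alone, is whether 4-aminophenyl or 4-carboxyphenyl on the same nitrogen gives a number well clear of that limit. Also open, as far as these compounds go, is whether the sulfamoyl group alone accounts for the readable value.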